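From tert-Butyl to Cyclopropyl on the Ring Nitrogen

A few compounds are considered here, and "the series" means these few. Any claim that something is new, unique, unknown or untested is made for them only; others in the source may bear on it.

Compound 2 `CC(C)(C)Nc1nc(N)c(C(=O)N=C(N)N)nc1Cl` stands lowest of the two compounds measured in an assay for inhibition of acid-sensing ion channel 3 (Homo sapiens), read by patch clamp, tested at 20 uM (on this read-out higher numbers stand for more inhibition at the one concentration tested (going by the name of the read-out) and lower numbers for less inhibition), where compound 2 gives 48%. Its nearest neighbour is compound 1 `C=CCNc1nc(N)c(C(=O)N=C(N)N)nc1Cl`, which in this assay gives 78%. Within the data shown here, the single measured step, a number 30 percentage points lower from compound 1 to compound 2 (beyond the scatter), lies beyond the scatter, and it is the only step that bears on the change now in question. Compound 3 `NC(N)=NC(=O)c1nc(Cl)c(NC2CC2)nc1N` differs from compound 2 by cyclopropyl in place of tert-butyl on a nitrogen on an aromatic ring. Since the tert-butyl group that enters in the measured step went with the lower number, removing it again in favour of another group on the same nitrogen is expected to move the number back upward, beyond the scatter, though not necessarily all the way to the allyl compound. Compound 3 is therefore expected to give 65%, within 45% to 85%. The step this estimate implies is a number 17 percentage points higher from compound 2 to compound 3 (beyond the scatter).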

Compound 3, a percentage reported as inhibition, at one concentration (the size of the read-out at that concentration, not a potency): 78%
Estimate against measurement, compound 3: 13 percentage points below; the measured number falls inside the stated range.
By their numbers in this assay, from the lowest: compound 2; then compounds 1 and 3 (each within the scatter of the next).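

Among these compounds, the earlier pair showed only that the group on this nitrogen can matter in this assay. Cyclopropyl in place of tert-butyl now gives a number 30 percentage points higher from compound 2 to compound 3 (beyond the scatter), while the step between the allyl and cyclopropyl compounds reads no change at the digits printed from compound 1 to compound 3 (within the scatter), so an open chain and a three-membered ring are not told apart here and, among these three compounds, only the tert-butyl compound stands apart. Nothing available here bears on the reason for this.

From the compounds shown here alone, whether a cyclobutyl or isopropyl group on the same nitrogen would fall with compound 2 or with compounds 1 and 3 remains open, as does the effect of a longer chain ending in an amine or a carboxylic acid. Each reading also comes from a single concentration, so the potencies of these compounds remain unknown.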